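Heteroaryl exchange on the pendant ring of a shared core

The source may hold more compounds than are shown below. What is called first, only, known or untested is meant among the compounds shown, and "the series" means these compounds.

Measured so far in an assay on microsomes from intestine for inhibition of acyl-CoA:cholesterol acyltransferase (Oryctolagus cuniculus); a higher number here means a weaker inhibitor, a lower number a stronger inhibitor:
compound 1, `O=C(Nc1c(F)cc(F)cc1F)N(Cc1ccc(-c2cccs2)cc1)C1CCCCCC1`: 18 nM
compound 2, `O=C(Nc1c(F)cc(F)cc1F)N(Cc1ccc(-c2ccsc2)cc1)C1CCCCCC1`: 23 nM
compound 3, `O=C(Nc1c(F)cc(F)cc1F)N(Cc1ccc(-n2cccc2)cc1)C1CCCCCC1`: 27 nM

Compound 3 holds the highest of the three numbers, but its separation from the others is small: a 1.5-fold higher number from compound 1 to compound 3 (0.18 log units; within the scatter) and a 1.2-fold higher number from compound 2 to compound 3 (0.07 log units; within the scatter) both fall within the scatter, as does a 1.3-fold higher number from compound 1 to compound 2 (0.11 log units; within the scatter). On these three numbers the three five-membered heteroaryl groups are indistinguishable.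

The next compound, compound 4, `O=C(Nc1c(F)cc(F)cc1F)N(Cc1ccc(-c2ccccn2)cc1)C1CCCCCC1`, carries the change (pyridin-2-yl in place of 1H-pyrrol-1-yl on an aromatic carbon). Unlike the three measured steps, this one moves from a five-membered to a six-membered aromatic ring, and no measured pair covers a ring of that size. The measured steps all bear on the same position, and all three stayed within the scatter when one five-membered heteroaryl group replaced another. The nearest guide is therefore that the position tolerates exchange of a small aromatic group, while the ring-size change adds uncertainty that the data cannot narrow.

For compound 4 in this assay a step of a 1.1-fold higher number from compound 3 to compound 4 (0.05 log units; within the scatter) is expected, with the estimate 30 nM and a range from 12 nM to 80 nM.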

Compound 4, half-maximal inhibitory concentration: 25 nM
For compound 4 the middle estimate is 1.2-fold (0.08 log units) above the measured one; the measured number falls inside the stated range.
By their numbers in this assay, from the lowest: compounds 1, 2, 4 and 3 (each within the scatter of the next).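

In this assay, for the compounds shown here, moving from a five-membered to a six-membered aromatic ring on the carbon para to a large group, a change no earlier pair covered, stays within the scatter (a 1.1-fold lower number from compound 3 to compound 4 (0.03 log units; within the scatter)). The comparisons with the two thiophene groups read the same way (a 1.1-fold higher number from compound 2 to compound 4 (0.04 log units; within the scatter)) and (a 1.4-fold higher number from compound 1 to compound 4 (0.14 log units; within the scatter)), so within this set, ring size joins the identity of the heteroaryl group as a change that produces no step beyond the scatter, and pyrrol-1-yl, thiophen-2-yl, thiophen-3-yl and pyridin-2-yl cannot be told apart at this position. No supporting evidence is available that would account for this flat response.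

On these data alone, all four groups are single aromatic rings, so it remains open whether the position would accept a saturated ring such as morpholine or piperidine, a carboxylic acid, a primary amine or a fused ring such as quinoline as readily. Also open, as far as these compounds go, is whether the ring nitrogen's placement matters, as pyridin-3-yl and pyridin-4-yl would show, and whether this flat response carries over to any setting beyond intestinal microsomes.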